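A few compounds are considered here, and "the series" means these few. Any claim that something is new, unique, unknown or untested is made for them only; others in the source may bear on it.

In a functional assay on NPC-TW01 cells (Homo sapiens) for inhibition, read by MTT assay, with a stated time of 72 h (on this read-out higher numbers stand for weaker inhibition of growth and lower numbers for stronger inhibition of growth), compound 3, `COC(=O)c1nc(C2CCCC2)n(-c2ccc(F)cc2)n1`, gives 10400 nM, the lower of the two numbers shown, although compound 2, `CCc1nc(C(=O)OC)nn1-c1ccc(F)cc1`, gives 15800 nM in this assay and the gap between them is within the scatter. Within the data shown here, the only measured step, a 1.5-fold lower number from compound 2 to compound 3 (0.18 log units; within the scatter), therefore tells little. Compound 1, `COC(=O)c1nc(C)n(-c2ccc(C(F)(F)F)cc2)n1`, reaches only a limit of the assay in this assay, > 100000 nM.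

Compound 4, `COC(=O)c1nc(C2CCCC2)n(-c2ccc(C(F)(F)F)cc2)n1`, differs from compound 3 in one place: trifluoromethyl in place of fluoro on an aromatic carbon. Among the measured compounds shown here, no measured step covers this exchange directly. For the measured compounds named here, the one clue comes from compound 1, which also carries a trifluoromethyl group and whose result, (the limit of > 100000 nM in this assay, at which 1 of the 3 values shown sits), hints that this group may go with weaker inhibition, yet compound 1 also carries methyl where compound 4 carries cyclopentyl, so the hint is not clean. The measured step of a 1.5-fold lower number from compound 2 to compound 3 (0.18 log units; within the scatter) concerns the other end of the shared core and does not bear on a fluoro to trifluoromethyl change.

The expected step of a 2.9-fold higher number from compound 3 to compound 4 (0.46 log units; beyond the scatter) is toward weaker inhibition, with wide uncertainty. Compound 4 is therefore estimated at 30000 nM in this assay, within a range of 8000 nM to 150000 nM.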

Compound 4, concentration for 50% growth inhibition: 56400 nM
Estimate against measurement, compound 4: 1.9-fold (0.27 log units) below, within the range that was stated.
By their numbers in this assay, from the lowest: compounds 3 and 2 (each within the scatter of the next); then compound 4. At a limit, above all of these: compound 1.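

With cyclopentyl held constant, the change on the aromatic carbon para to a large group can now be read directly in this assay: trifluoromethyl in place of fluoro gives a modest step toward weaker inhibition of growth (a 5.4-fold higher number from compound 3 to compound 4 (0.73 log units; beyond the scatter)). This is one pair, so it shows the direction of the exchange only with cyclopentyl on the shared core, and no reason for that direction can be drawn from these numbers. Compound 1 stands at a limit of the assay rather than at a number, so the exchange of methyl for cyclopentyl, with trifluoromethyl held constant, can be read only as a floor (an at least 1.7-fold lower number from compound 1 to compound 4 (0.24 log units; that floor lies within the scatter)), which leaves its real size unknown: the limit of > 100000 nM in this assay, at which 1 of the 4 values shown sits.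

From the compounds shown here alone, how chloro, methoxy or a nitrile on that same aromatic carbon would compare with fluoro and trifluoromethyl stays open, as does whether the step seen here would hold with ethyl in place of cyclopentyl. All the compounds shown also keep the same methyl ester, so the effect of a carboxylic acid or an amide in its place remains open too.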